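A few compounds are considered here, and "the series" means these few. Any claim that something is new, unique, unknown or untested is made for them only; others in the source may bear on it.

Among the measured compounds shown here, in a functional assay on HGC-27 cells (Homo sapiens) for cytotoxicity, read by MTT assay, with a stated time of 72 h (on this read-out higher numbers stand for weaker inhibition and lower numbers for stronger inhibition), compound 1 `O=C1C=CCC/C1=C\C=C\c1ccc(F)cc1` gives 2300 nM and compound 2 `COc1ccccc1/C=C/C=C1\CCC=CC1=O` gives 3100 nM which places the two within the usual scatter of each other, so compound 1 stands level with the only other measured compound. For the measured compounds named here, compound 3 `CC(=O)Oc1ccc(/C=C/C=C2\CCC=CC2=O)cc1` keeps the core of compound 1 but carries acetoxy in place of fluoro on an aromatic carbon, para to a large group acetoxy in place of fluoro on an aromatic carbon and no measured pair shows this change on its own. In this assay the expected step of a 1.1-fold higher number from compound 1 to compound 3 (0.04 log units; within the scatter) is no larger than the scatter, with no clear direction. Compound 3 is estimated at 2500 nM with an expected range from 900 nM to 7000 nM in repeat measurements.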

Compound 3, half-maximal inhibitory concentration: 4900 nM
The estimate for compound 3 lay 2.0-fold (0.29 log units) below the measured number; low and high end bracket the measured number.
By their numbers in this assay, from the lowest: compounds 1, 2 and 3 (each within the scatter of the next, the first and the last beyond it).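

Acetoxy in place of fluoro on an aromatic carbon, para to a large group, gives a 2.1-fold higher number from compound 1 to compound 3 (0.33 log units; beyond the scatter) in this assay, so what sits at this position can shift the read-out, here towards weaker inhibition. This single modest step is too little to establish a trend. Nothing measured on these compounds explains the shift.

The compounds shown leave open how an amine or a carboxylic acid at this same position would compare. They also leave open whether this change would shift the number in the same direction on the core of another compound.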